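Pentyl for Butoxy on a Shared Core

The source may report more compounds than this note shows. Statements on the series, on what has been measured and on what is new or still open speak of the compounds shown alone.

Compound 1 `CCCCOc1nc(N)c2[nH]c(=O)n(Cc3ccccc3)c2n1`: 0.001 uM
Compound 2 `CCCCOc1nc(N)c2nc(S)n(Cc3ccccc3)c2n1`: 0.001 uM

Both values come from a functional assay on cells (Splenocyte, Mus musculus, strain C3H/HeJ), with a stated time of 18 h; a lower number here means that less compound is needed, a higher number that more compound is needed for the effect. In it compound 1 gives 0.001 uM and compound 2 gives 0.001 uM; the two numbers are level at the digits shown, so compound 1 stands within the scatter of compound 2 and no order between the two can be read from them. Within the data shown here, compound 1 and compound 2 differ in a part of the core away from the side chain, and no step between them is computed here.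

Compound 3 `CCCCCc1nc(N)c2[nH]c(=O)n(Cc3ccccc3)c2n1` is not yet measured. Relative to compound 1 it carries pentyl in place of butoxy on an aromatic carbon. Among the measured compounds shown here, no measured pair in this set provides a step of the kind that could guide this change, so its size has to be guessed rather than read. The expectation is a small move toward a higher number, of about a 3.0-fold higher number from compound 1 to compound 3 (0.48 log units; beyond the scatter), a step that may well remain within the scatter. Compound 3 is therefore estimated at 0.003 uM, with a range from 0.0005 uM to 0.02 uM.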

Compound 3, minimum effective concentration: 0.01 uM
Beside the measured number, compound 3's estimate is 3.3-fold (0.52 log units) below it, and the stated range covers the measured number.
By their numbers in this assay, from the lowest: compounds 1 and 2 (each within the scatter of the next); then compound 3.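

Swapping butoxy for pentyl on the aromatic carbon between two ring nitrogen atoms gives a 10-fold higher number from compound 1 to compound 3 (1.00 log units; beyond the scatter) in this assay, so this position responds to the change, which compounds 1 and 2 could not show because they share butoxy there. Butoxy and pentyl both count 5 heavy atoms and no ring, so the swap replaces oxygen with carbon at an unchanged heavy-atom count and lowers the hydrogen-bond acceptor count from 1 to 0, yet compound 3 still records a value of 0.01 uM. No accompanying measurement accounts for the shift, so the data do not say what lies behind it.

The compounds shown leave open whether other groups on this carbon, such as a propoxy or hexyloxy chain, a butylamino group or a butylthio group, would stay closer to butoxy or move further from it. They also leave open whether pentyl in place of butoxy would produce a step of similar size on the core of compound 2, and whether the same step would appear with a substituted benzyl group on the shared core.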